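Furan to pyrazole on the biaryl of an imidazoline ether

The source may hold more compounds than are shown below. What is called first, only, known or untested is meant among the compounds shown, and "the series" means these compounds.

Measured compounds:
Compound 1, `c1ccc(-c2ccncc2)c(OCC2=NCCN2)c1`: < 100000 nM
Compound 2, `c1ccc(-c2ccoc2)c(OCC2=NCCN2)c1`: 5.01 nM

Of the compounds shown here, two have been tested in a functional assay for activation of Alpha-1D adrenergic receptor (Homo sapiens), read by calcium flux; a higher number here means that more compound is needed for the effect, a lower number that less compound is needed. Compound 1, `c1ccc(-c2ccncc2)c(OCC2=NCCN2)c1`, gives only a limit of the assay, < 100000 nM, and no number (the limit of < 100000 nM in this assay, at which 1 of the 2 values shown sits). Among the measured compounds shown here, compound 2, `c1ccc(-c2ccoc2)c(OCC2=NCCN2)c1`, gives 5.01 nM in this assay, the only number among the two results. The step that the limit leaves unreadable from compound 1 to compound 2 cannot be sized because compound 1 sits at the limit.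

Compound 3, `c1ccc(-c2cc[nH]n2)c(OCC2=NCCN2)c1`, has not yet been measured. Compared with compound 2, it carries 1H-pyrazol-3-yl in place of furan-3-yl on an aromatic carbon. For the measured compounds named here, the only measured step that bears on this position is the one from compound 1 to compound 2, and it shows that exchanging the five-membered furan-3-yl for a six-membered nitrogen heterocycle took compound 1 out of the readable range, without giving a usable size. Going by the values given here, no measured step compares two five-membered heterocycles at this site.

On this thin basis, compound 3 is expected to lose activity relative to compound 2 in this assay, with a step of about a 30-fold higher number from compound 2 to compound 3 (1.48 log units; beyond the scatter), though the uncertainty is wide. Compound 3 is therefore estimated at 150 nM, in a range from 10 nM to 5000 nM.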

Compound 3, half-maximal effective concentration: < 100000 nM
Compound 3 was reported as a limit; the forecaster's own chance of this, stated with the estimate: 25%; the middle value does not contradict the limit.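

Compound 3 gives only a limit in this assay, so no step from compound 1 or compound 2 to compound 3 can be read: the limit of < 100000 nM in this assay, at which 2 of the 3 values shown sit.

The compounds shown leave open what number compound 1 and compound 3 would give, and so how pyridin-4-yl and 1H-pyrazol-3-yl compare with furan-3-yl at this place.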